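The source may hold more compounds than are shown below. What is called first, only, known or untested is meant among the compounds shown, and "the series" means these compounds.

Measured in an ADME assay on FHC cells (Homo sapiens) for cytotoxicity, read by MTT assay, with a stated time of 72 h; on this read-out higher numbers stand for weaker inhibition and lower numbers for stronger inhibition:
Compound 1 `C=CC(=O)Nc1cc2c(Nc3ccc(OCc4cccc(F)c4)c(Cl)c3)ncnc2cc1OCc1cn(CCCC(=O)NO)nn1`: > 25000 nM (a limit)
Compound 2 `C=CC(=O)Nc1cc2c(Nc3ccc(OCc4cccc(F)c4)c(Cl)c3)ncnc2cc1OCc1cn(CCCCC(=O)NO)nn1`: > 25000 nM (a limit)

Compound 2 stands at the limit of > 25000 nM in this assay, at which 2 of the 2 values shown sit, so it offers no exact number as a starting point. Compound 3 `C=CC(=O)Nc1cc2c(Nc3ccc(F)c(Cl)c3)ncnc2cc1OCc1cn(CCCCC(=O)NO)nn1` differs from compound 2 at one place: fluoro in place of (3-fluorobenzyl)oxy on an aromatic carbon. Here fluoro takes the place of (3-fluorobenzyl)oxy on an aromatic carbon, ortho to a chloro group.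

Among the measured compounds shown here, the only measured step is a step that the two limits leave unreadable from compound 1 to compound 2. It lies in the chain, not at this aromatic carbon, so it gives no guide to the size of this change. The expectation therefore rests on compound 2 at > 25000 nM, a limit, and no step beyond the usual scatter is expected in either direction in this assay.

For compound 3 the estimated value is 30000 nM, with an expected range of 12000 nM to 60000 nM. This estimate means an expected step that the limit leaves unreadable from compound 2 to compound 3.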

Compound 3, half-maximal inhibitory concentration: > 25000 nM
Compound 3: a limit, no number (the forecaster's own chance of this, stated with the estimate: 65%); the middle value is on the limit's open side.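

No step can be read from compound 2 to compound 3 in this assay, since each gives only a limit and no number: the limit of > 25000 nM in this assay, at which 3 of the 3 values shown sit.

The compounds shown leave open how far each lies past that limit, and so whether fluoro in place of (3-fluorobenzyl)oxy changes the read-out at all.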